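The source may report more compounds than this note shows. Statements on the series, on what has been measured and on what is new or still open speak of the compounds shown alone.

Measured so far:
compound 1 `COc1cc(CCc2ccc(Cl)c(Cl)c2)cc(OC)c1O`: 16100 nM
compound 2 `COc1cc(CCc2ccccc2F)cc(OC)c1O`: 1030 nM

In a functional assay on HepG2 cells (Homo sapiens) for antiproliferative activity, read by MTT assay, with a stated time of 72 h (on this read-out higher numbers stand for weaker inhibition and lower numbers for stronger inhibition), compound 2 gives the lowest of the two numbers; the value of compound 1 sits well above it, beyond the scatter. Compound 3 `COc1cc(CCc2ccccc2Cl)cc(OC)c1O` is not yet measured. It differs from compound 2 by chloro in place of fluoro on an aromatic carbon. Going by the values given here, no step between measured compounds isolates this change, so the expectation rests on compound 2 alone. A step of a 1.3-fold lower number from compound 2 to compound 3 (0.11 log units; within the scatter) is expected to be small, within the scatter, with no firm direction. Compound 3 is estimated at 800 nM, with a range from 300 nM to 2500 nM.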

Compound 3, half-maximal inhibitory concentration: 2190 nM
Estimate against measurement, compound 3: 2.7-fold (0.44 log units) below, and the stated range covers the measured number.
By their numbers in this assay, from the lowest: compound 2; then compound 3; then compound 1.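

In this assay, going by these compounds alone, the exchange of fluoro for chloro on an aromatic carbon, ortho to a large group, gives a 2.1-fold higher number from compound 2 to compound 3 (0.33 log units; beyond the scatter) and is the first single-place comparison. The step is modest, but it shows that this position distinguishes between the two halogens, with fluoro giving the lower number of the pair. No measurement at hand accounts for the step.

Still open, on these data alone, is how a methoxy group or an amine would read at this position. Also open, as far as these compounds go, is whether the same exchange elsewhere on this ring gives a step of similar size or direction.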